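Swapping an Isopropyl for a Propyl on the Amide

The compounds below may be only part of what the source reports. "The series", "measured", "known", "first", "only" and "open" are said of these compounds alone.

Measured compounds:
Compound 1, `CCCNS(=O)(=O)c1ccc(Nc2ncc3c(n2)N(C2CCCC2)[C@H](CC)C(=O)N3C)cc1`, gives 459 nM in a functional assay on HeLa cells (Homo sapiens) for antiproliferative activity, read by CCK-8 assay, with a stated time of 72 h; a lower number here means a stronger inhibitor of growth, a higher number a weaker inhibitor of growth.
Compound 2, `CCC1C(=O)N(C)c2cnc(-n3ccc4cc(C(=O)NC)ccc43)nc2N1c1ccn(C)n1`, gives 6330 nM in this assay.
Compound 3, `CC[C@@H]1C(=O)N(C)c2cnc(-n3ccc4cc(C(=O)NC(C)C)ccc43)nc2N1C1CCCC1`, gives 292 nM in this assay.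

Compound 3 has the lowest number of the three, though its gap to compound 1 lies within the scatter, so the two cannot be ranked; only compound 2 stands clearly apart with a much higher number. Compound 4, `CCCNC(=O)c1ccc2c(ccn2-c2ncc3c(n2)N(C2CCCC2)[C@H](CC)C(=O)N3C)c1`, is built from the same atoms as compound 3, joined differently: propyl in place of isopropyl on an amide-type nitrogen. For the measured compounds named here, no measured pair shows such a change, so no step size is known. A change of this kind is expected to give a step no larger than the scatter, with no clear direction. Compound 4 is therefore estimated at 350 nM, within 150 nM to 800 nM, a step of a 1.2-fold higher number from compound 3 to compound 4 (0.08 log units; within the scatter).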

Compound 4, concentration for 50% growth inhibition: 238 nM
For compound 4 the middle estimate is 1.5-fold (0.17 log units) above the measured one, within the range that was stated.
By their numbers in this assay, from the lowest: compounds 4, 3 and 1 (each within the scatter of the next); then compound 2.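

Propyl in place of isopropyl on the amide-type nitrogen gives a 1.2-fold lower number from compound 3 to compound 4 (0.09 log units; within the scatter) in this assay. For the compounds shown here, this is the first measured pair that isolates this position, and it shows that the two chains cannot be told apart here: rearranging these carbons leaves no change beyond the scatter. Nothing measured here bears on the reason for this result.

Going by these compounds, what remains open is whether a bigger change on this nitrogen, such as a longer chain like hexyl, a cyclopropyl ring or a chain ending in a carboxylic acid, would move the number. Whether the same swap behaves alike on another core is also unknown.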